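This account rests on a few compounds, and the source may have more. Where it says the series, first, only, none or still open, it means among the compounds named here.

Measured so far:
compound 1 `COc1ccc(CN2CCC(CCNC(=O)/C=C/c3cc(C(C)(C)C)c(O)c(C(C)(C)C)c3)CC2)cc1` — 72500 nM
compound 2 `CC(C)(C)c1cc(/C=C/C(=O)NCCC2CCN(Cc3ccccc3Cl)CC2)cc(C(C)(C)C)c1O` — 72100 nM

In an assay on isolated protein for inhibition of Amine oxidase [flavin-containing] A (Homo sapiens), read by fluorescence, with stated times of 15 min and 20 min (a higher number here means a weaker inhibitor, a lower number a stronger inhibitor), compound 1 gives 72500 nM, the highest of the two numbers at hand; compound 2 gives 72100 nM, and the step of a 1.0-fold lower number from compound 1 to compound 2 (0.00 log units; within the scatter) lies within the scatter, so the two values cannot be ordered.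

Compound 3 `CC(C)(C)c1cc(/C=C/C(=O)NCCC2CCN(Cc3ccc(Br)cc3)CC2)cc(C(C)(C)C)c1O` is not yet measured in this assay. It differs from compound 1 by bromo in place of methoxy on an aromatic carbon: 4-methoxybenzyl becomes 4-bromobenzyl on the saturated chain carbon bound to the amine nitrogen in the ring. Among the measured compounds shown here, the one step that bears on this is a 1.0-fold lower number from compound 1 to compound 2 (0.00 log units; within the scatter), which changed the substituent on the same six-membered aromatic ring of carbon only and moved the number nowhere beyond the scatter. The evidence is a single flat step, so for compound 3 no move beyond the scatter is expected in this assay.

Compound 3 is therefore estimated at 72000 nM, with an expected range of 30000 nM to 170000 nM. The expected step is a 1.0-fold lower number from compound 1 to compound 3 (0.00 log units; within the scatter).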

Compound 3, half-maximal inhibitory concentration: 73200 nM
Compound 3: the middle estimate sits 1.0-fold (0.01 log units) below what was measured; measured number inside the range.
By their numbers in this assay, from the lowest: compounds 2, 1 and 3 (each within the scatter of the next).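

In this assay, bromo in place of methoxy on an aromatic carbon, para to a large group, gives a 1.0-fold higher number from compound 1 to compound 3 (0.00 log units; within the scatter) and so tests this position directly: a change from 2 heavy atoms to 1 and the loss of 1 hydrogen-bond acceptor leaves the number within the scatter. The second comparison, a 1.0-fold higher number from compound 2 to compound 3 (0.01 log units; within the scatter), adds that 4-bromophenyl and 2-chlorophenyl cannot be told apart here, so all three substituted benzyl groups give values that cannot be ordered. No measurement at hand accounts for this flat response.

As far as these compounds go, whether an amine or a carboxylic acid on this aromatic ring would move the number beyond the scatter remains open. So does the effect of a longer chain between the ring nitrogen and the aromatic ring.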